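The source may report more compounds than this note shows. Statements on the series, on what has been measured and on what is new or still open speak of the compounds shown alone.

Measured compounds in an ADME assay on HUVEC cells (Homo sapiens) for antiproliferative activity, read by MTT assay, with a stated time of 48 h; a higher number here means a weaker inhibitor, a lower number a stronger inhibitor:
- compound 1 `Cc1cc(C)cc(-n2nncc2CN2C(=O)C3(C(C#N)=C(N)Oc4c3c3nc5ccccc5nc3c3ccccc43)c3ccccc32)c1`; in this assay compound 1 gives only a limit, > 50000 nM
- compound 2 `N#CC1=C(N)Oc2c(c3nc4ccccc4nc3c3ccccc23)C12C(=O)N(Cc1cnnn1-c1cc(Cl)ccc1Cl)c1ccccc12`; in this assay compound 2 gives only a limit, > 50000 nM
- compound 3 `N#CC1=C(N)Oc2c(N)cc3nc4ccccc4nc3c2C12C(=O)N(Cc1cnnn1-c1cccc(Br)c1)c1ccccc12`; in this assay compound 3 gives only a limit, > 50000 nM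

Going by the values given here, all three values sit at the same limit of this assay, (the limit of > 50000 nM in this assay, at which 3 of the 3 values shown sit), so no compound can be ordered against another. Among the compounds with values here, the one step between measured compounds that differ in one place, a step that the two limits leave unreadable from compound 1 to compound 2, cannot be read because both ends are limits.

Compound 3 therefore stands at the limit, with no number of its own, and the other two values shown are limits as well. The unmeasured compound 4 `N#CC1=C(N)Oc2c(N)cc3nc4ccccc4nc3c2C12C(=O)N(Cc1cnnn1-c1ccc(Cl)cc1Cl)c1ccccc12` differs from compound 3 only on the aromatic nitrogen of the five-membered aromatic ring with 3 nitrogen: 2,4-dichlorophenyl in place of 3-bromophenyl on an aromatic nitrogen. Within the data shown here, the only comparable step, the exchange of one halogenated or methylated phenyl for another on that same nitrogen, is unreadable, and no measured step gives a size to expect. With every value shown at the limit, compound 4 is expected to stay there too. Compound 4 is expected to give 80000 nM in this assay, most likely as a limit again, within 30000 nM to 300000 nM. The expected step that the limit leaves unreadable from compound 3 to compound 4 is accordingly none beyond the scatter.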

Compound 4, half-maximal inhibitory concentration: > 50000 nM
Compound 4 gave a limit, no number; the forecaster's own chance of this, stated with the estimate: 85%; the middle value does not contradict the limit.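

Compound 3 and compound 4 both give only a limit in this assay, so no step can be read between them: the limit of > 50000 nM in this assay, at which 4 of the 4 values shown sit.

The compounds shown leave open whether any substituted phenyl on that aromatic nitrogen would give a readable number in this assay.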